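The source may hold more compounds than are shown below. What is called first, only, known or untested is meant among the compounds shown, and "the series" means these compounds.

Compound 1 `CN1C(=S)N(C2CCCCC2)C(=O)/C1=C\c1ccc(N(C)C)cc1` and compound 2 `CCN(CC)c1ccc(/C=C2\C(=O)N(C3CCCCC3)C(=S)N2C)cc1` share one core and differ only in the amine on the aromatic ring. In an assay on isolated protein for inhibition of NADPH oxidase 2 (Homo sapiens), read by chemiluminescence, in the presence of a further agent that is not named here (a lower number here means a stronger inhibitor, a higher number a weaker inhibitor), compound 1 gives 3580 nM, and compound 2 gives 5660 nM. The step of a 1.6-fold higher number from compound 1 to compound 2 (0.20 log units; within the scatter) lies within the scatter. Of the two numbers shown, the one for compound 2 is the larger, but its gap to compound 1 is within the scatter, so the two cannot be told apart.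

Compound 3 `CCN(CC)c1ccc(/C=C2\C(=O)N(c3ccccc3)C(=S)N2C)cc1` keeps the diethylamino group of compound 2 and differs from it in one place: phenyl in place of cyclohexyl on an amide-type nitrogen in a ring. Going by the values given here, no measured step touches the group on that ring nitrogen; the only step at hand, a 1.6-fold higher number from compound 1 to compound 2 (0.20 log units; within the scatter), concerns the amine on the aromatic ring and was within the scatter, so it gives no guide to the size or direction of the exchange of cyclohexyl for phenyl. Compound 3 is therefore expected to give a number near that of compound 2. The step of a 1.1-fold higher number from compound 2 to compound 3 (0.03 log units; within the scatter) is expected to stay within the scatter, with the uncertainty kept wide. The estimate for compound 3 is 6000 nM, with a range from 2000 nM to 18000 nM.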

Compound 3, half-maximal inhibitory concentration: 1960 nM
Compound 3: middle estimate off by 3.1-fold (0.49 log units), on the high side, outside the stated range (below it).
By their numbers in this assay, from the lowest: compounds 3, 1 and 2 (each within the scatter of the next, the first and the last beyond it).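

Going by these compounds alone, the group on the amide-type nitrogen in a ring is the first place in these compounds where a single exchange moves the number in this assay beyond the scatter: with the diethylamino group held fixed, phenyl in place of cyclohexyl gives a modest step (a 2.9-fold lower number from compound 2 to compound 3 (0.46 log units; beyond the scatter)). The exchange of the amine on the aromatic ring had stayed within the scatter (a 1.6-fold higher number from compound 1 to compound 2 (0.20 log units; within the scatter)), so only this ring nitrogen has so far shown a response that can be read. The two groups match in the computed counts, with six carbon atoms, one six-membered ring and no hydrogen-bond donors or acceptors, and they differ in that the entering ring is aromatic and the leaving ring is not, but nothing at hand explains the direction of the step.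

From the compounds shown here alone, whether the same exchange would give a similar step with the dimethylamino group of compound 1 in place remains open, since it rests on one pair. Also open, going by these compounds, is how this ring nitrogen would respond to a benzyl group, a pyridyl ring or a longer alkyl chain, or to a fluorine or methoxy group on the phenyl ring.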